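The compounds below may be only part of what the source reports. "The series", "measured", "known", "first", "only" and "open" are said of these compounds alone.

Series notes. The shared core carries a dimethylamide-bearing pyridine linked through a propylamine chain to an arylpiperazine; the aryl ring is the only point varied. In a functional assay for antagonist activity at Alpha-1A adrenergic receptor (Oryctolagus cuniculus) (a lower number here means tighter binding, a higher number weaker binding), compound 1 `CN(C)C(=O)c1cccnc1NCCCN1CCN(c2ccccc2)CC1` gives 6.31 nM, compound 2 `Cc1ccccc1N1CCN(CCCNc2ncccc2C(=O)N(C)C)CC1` gives 2 nM and compound 3 `CC(C)c1ccccc1N1CCN(CCCNc2ncccc2C(=O)N(C)C)CC1` gives 0.398 nM. The step from compound 1 to compound 2 is a 3.2-fold lower number from compound 1 to compound 2 (0.50 log units; beyond the scatter), that from compound 1 to compound 3 is a 16-fold lower number from compound 1 to compound 3 (1.20 log units; beyond the scatter), and that from compound 2 to compound 3 is a 5.0-fold lower number from compound 2 to compound 3 (0.70 log units; beyond the scatter). Compound 3 therefore holds the lowest number of the three.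

Compound 4 `COc1cc(C)ccc1N1CCN(CCCNc2ncccc2C(=O)N(C)C)CC1` differs from compound 3 in one place: 2-methoxy-4-methylphenyl in place of 2-isopropylphenyl on an amine nitrogen in a ring. Within the data shown here, the isopropyl group that leaves is the one whose introduction gave a 5.0-fold lower number from compound 2 to compound 3 (0.70 log units; beyond the scatter); the methoxy group that enters has no counterpart among the measured compounds, and the methyl on the entering ring sits where none of the measured rings carries a group, so the measured steps give only partial guidance. Compound 4 is expected to return toward the region of compound 2, a step of a 3.8-fold higher number from compound 3 to compound 4 (0.58 log units; beyond the scatter) in this assay. The estimate for compound 4 is 1.5 nM, with a range from 0.4 nM to 6 nM.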

Compound 4, dissociation constant: 0.794 nM
Estimate against measurement, compound 4: 1.9-fold (0.28 log units) above; the range from low to high includes it.
By their numbers in this assay, from the lowest: compounds 3 and 4 (each within the scatter of the next); then compound 2; then compound 1.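

In this assay, replacing 2-isopropylphenyl with 2-methoxy-4-methylphenyl on the ring amine nitrogen gives a 2.0-fold higher number from compound 3 to compound 4 (0.30 log units; within the scatter) and so does not separate the two groups, although the entering group contains an oxygen and a hydrogen-bond acceptor. Set against the simpler rings, the same group gives a 2.5-fold lower number from compound 2 to compound 4 (0.40 log units; beyond the scatter) and a 7.9-fold lower number from compound 1 to compound 4 (0.90 log units; beyond the scatter) in this series, so an aryl group carrying only carbon substituents is not required for a number in the range of compound 3. No available measurement accounts for these steps.

The methoxy and methyl groups enter together, leaving their separate contributions unresolved. Also open, from the compounds shown here alone, is how the number would respond to a chlorine or a trifluoromethyl group on the aryl ring, or to a longer chain in the linker.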